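Methyl for Fluoro on a Shared Indole-Quinoline Core

The compounds below may be only part of what the source reports. "The series", "measured", "known", "first", "only" and "open" are said of these compounds alone.

Measured compounds:
compound 1, `Fc1ccc2c(-c3ccc4ccccc4n3)c[nH]c2c1F`, 0.167 h
compound 2, `Cc1cc(F)cc2c(-c3ccc4ccccc4n3)c[nH]c12`, 1.1 h
compound 3, `Cc1ccc2c(-c3ccc4ccccc4n3)c[nH]c2c1F`, 0.25 h

All three were tested in an ADME assay on microsomes from liver (Homo sapiens) for metabolic stability, using NADPH, with a stated time of 40 min, tested at 2 uM; on this read-out lower numbers stand for a shorter-lived compound and higher numbers for a longer-lived compound. Compound 2 gives the highest number of the three, and its steps to compound 3 and to compound 1 both lie beyond the scatter. How the core of compound 1 differs from that of compound 2 is not broken down here. From compound 1 to compound 3 the change is methyl in place of fluoro on an aromatic carbon, and it made a 1.5-fold higher number from compound 1 to compound 3 (0.18 log units; within the scatter). Compound 4, `Cc1cc(C)c2[nH]cc(-c3ccc4ccccc4n3)c2c1`, carries the same kind of change from compound 2, (methyl in place of fluoro on an aromatic carbon), though here the place is meta to a methyl group rather than ortho to a fluoro group. Resting on a 1.5-fold higher number from compound 1 to compound 3 (0.18 log units; within the scatter), a modest step of a 1.3-fold higher number from compound 2 to compound 4 (0.10 log units; within the scatter) is expected, and compound 4 is estimated at 1.4 h in this assay.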

Compound 4, half-life: 1.57 h
Beside the measured number, compound 4's estimate is 1.1-fold (0.05 log units) below it; the measured number falls inside the stated range.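

In this assay, methyl in place of fluoro on an aromatic carbon behaved alike on the two cores: the same change on two cores in this assay, a 1.5-fold higher number (0.18 log units; within the scatter) from compound 1 to compound 3 and a 1.4-fold higher number (0.15 log units; within the scatter) from compound 2 to compound 4, 1.0-fold (0.02 log units) apart, within the scatter of two such steps. The new step, a 1.4-fold higher number from compound 2 to compound 4 (0.15 log units; within the scatter), thus agrees with the earlier one, but each step lies within the scatter, so the pair shows that this change left the half-life within the scatter on both cores, not that methyl lengthens it. Two cores also cannot show that the result holds on other cores or at other places on the ring.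

The compounds shown leave open whether an ethyl group, a methoxy group or a nitrile in place of the fluoro would give the same result as methyl. They also leave open which single change separates the core of compound 1 from that of compound 2.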